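Swapping the sulfur-linked side chain for an imidazole arm

A few compounds are considered here, and "the series" means these few. Any claim that something is new, unique, unknown or untested is made for them only; others in the source may bear on it.

Compound 1, `CC(C)c1n[nH]c2c(NCc3ccc(-c4ccccn4)cc3)nc(SCCC(N)=O)nc12` — in a functional assay on HT cells (Homo sapiens) for antiproliferative activity, read by fluorescence, with a stated time of 72 h (a higher number here means a weaker inhibitor of growth, a lower number a stronger inhibitor of growth), compound 1 gives 120 nM.
Compound 2, `CC(C)c1n[nH]c2c(NCc3ccc(-c4ccccn4)cc3)nc(SCC(O)CO)nc12` — compound 2 gives 21 nM.
Compound 3, `CC(C)c1n[nH]c2c(NCc3ccc(-c4ccccn4)cc3)nc(SC[C@H](O)CN)nc12` — compound 3 gives 63 nM.

Among these three numbers compound 3 stands second highest. Its nearest neighbour is compound 1, and the step of a 1.9-fold lower number from compound 1 to compound 3 (0.28 log units; within the scatter) stays within the scatter, so the two cannot be ordered. Compound 2 is furthest away: the step of a 3.0-fold higher number from compound 2 to compound 3 (0.48 log units; beyond the scatter) lies beyond the scatter.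

Compound 4, `CC(C)c1n[nH]c2c(NCc3ccc(-c4ccccn4)cc3)nc(SCCn3ccnc3)nc12`, has not yet been measured. Against compound 3 the difference is (1H-imidazol-1-yl)methyl in place of 2-amino-1-hydroxyethyl on a saturated chain carbon bound to a sulfur. All three measured steps alter this same place: a 5.7-fold lower number from compound 1 to compound 2 (0.76 log units; beyond the scatter), a 1.9-fold lower number from compound 1 to compound 3 (0.28 log units; within the scatter) and a 3.0-fold higher number from compound 2 to compound 3 (0.48 log units; beyond the scatter). Yet none of them brings in an aromatic ring, and every measured variant keeps at least one hydrogen-bond donor on the chain, whereas compound 4 carries none. The measured steps therefore set a scale — from within the scatter up to a modest change — but give no direction for this particular exchange.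

For compound 4 the estimated step from compound 3 is a 1.3-fold higher number from compound 3 to compound 4 (0.10 log units; within the scatter), with the direction uncertain. Compound 4 is expected to give 80 nM, likely between 25 nM and 250 nM.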

Compound 4, concentration for 50% growth inhibition: 155 nM
Compound 4: the middle estimate sits 1.9-fold (0.29 log units) below what was measured, and the stated range covers the measured number.
By their numbers in this assay, from the lowest: compound 2; then compounds 3, 1 and 4 (each within the scatter of the next, the first and the last beyond it).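

In this assay, among the compounds shown here, the change to (1H-imidazol-1-yl)methyl, the only group at this place among the four compounds with an aromatic ring and the only one with 0 hydrogen-bond donors, gives a 2.5-fold higher number from compound 3 to compound 4 (0.39 log units; beyond the scatter) and a 7.4-fold higher number from compound 2 to compound 4 (0.87 log units; beyond the scatter). With 1H-imidazol-1-yl in place of carbamoyl, the result is a 1.3-fold higher number from compound 1 to compound 4 (0.11 log units; within the scatter), so the chains of these two compounds cannot be ordered, and a ring-bearing chain without donors fits within the range the earlier chains had set, while compound 2 keeps a lower number than each of the other three, all its steps lying beyond the scatter. No accompanying measurement bears on what lies behind these steps.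

The compounds shown leave open whether the ring itself or the loss of the hydroxyl and amino groups accounts for the step from compound 3 to compound 4, since both differences arrive together. They also do not show how a carboxylic acid at the end of the chain, a longer chain carrying the imidazole, or a phenyl ring in place of the imidazole would compare at this place.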